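The source may report more compounds than this note shows. Statements on the series, on what has been measured and on what is new or still open speak of the compounds shown alone.

Compound 1 `C=CCOc1cc(OC)c(C(=O)/C=C/c2ccccc2Br)c(OCC=C)c1` and compound 2 `C=CCOc1cc(OC)c(C(=O)/C=C/c2ccccc2F)c(OCC=C)c1` share one core, while compound 3 `COc1cc(O)cc(O)c1C(=O)/C=C/c1ccccc1Br` is built on another; the difference between the two cores is not broken down here. In a toxicity assay on cells (Macrophage, Mus musculus, strain BALB/c) for cytotoxicity, read by MTT assay (a higher number here means a weaker inhibitor, a lower number a stronger inhibitor), compound 1 gives 5400 nM, compound 2 gives 13300 nM, and compound 3 gives 14600 nM. The change from compound 1 to compound 2 is fluoro in place of bromo on an aromatic carbon and it brought a 2.5-fold higher number from compound 1 to compound 2 (0.39 log units; beyond the scatter). Compound 4 `COc1cc(O)cc(O)c1C(=O)/C=C/c1ccccc1F` stands to compound 3 as compound 2 stands to compound 1: fluoro in place of bromo on an aromatic carbon. The place of the change reads the same in both pairs, so this is the same change, seen once before. Going by the values given here, for compound 4 the step is expected to be a 2.1-fold higher number from compound 3 to compound 4 (0.31 log units; beyond the scatter), because the only earlier example gave a 2.5-fold higher number from compound 1 to compound 2 (0.39 log units; beyond the scatter) in this assay and nothing more is known about this change. Compound 4 is therefore expected to give 30000 nM, with a likely range from 12000 nM to 80000 nM.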

Compound 4, half-maximal inhibitory concentration: 16000 nM
For compound 4 the middle estimate is 1.9-fold (0.27 log units) above the measured one; the range from low to high includes it.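

In this assay, putting fluoro in place of bromo on the second core gave a 1.1-fold higher number from compound 3 to compound 4 (0.04 log units; within the scatter), so this pair cannot be told apart in this read-out. Set beside the earlier step, the result does not differ from it by more than repeated measurements would: the same change on two cores in this assay, a 2.5-fold higher number (0.39 log units; beyond the scatter) from compound 1 to compound 2 and a 1.1-fold higher number (0.04 log units; within the scatter) from compound 3 to compound 4, 2.2-fold (0.35 log units) apart, within the scatter of two such steps. This agrees with the change carrying over from one core to the other, but two pairs cannot prove that it does, nor can they show whether the size of the step depends on the core.

The compounds shown leave open what chloro, a methyl group or an amine would do in the same place on the 2-bromophenyl ring. They also leave open whether this agreement would hold on any further core.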